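Sulfonyl aryl replacement on the trifluoromethyl hydroxyamide core

The source may hold more compounds than are shown below. What is called first, only, known or untested is meant among the compounds shown, and "the series" means these compounds.

Notes on the series built around the trifluoromethyl hydroxyamide core of compound 1 `CC(O)(C(=O)Nc1ccc(S(=O)(=O)c2cccc(O)c2)cc1)C(F)(F)F`. In a functional assay (Cavia porcellus) with sulfonylurea receptors; K-ATP channels (Homo sapiens) as the target (a lower number here means a stronger inhibitor, a higher number a weaker inhibitor), compound 1 gives 18000 nM, the highest number of the three measured here. Compound 2 `CC(O)(C(=O)Nc1ccc(C(=O)c2ccccc2)cc1C#N)C(F)(F)F`, which carries a benzoyl group and a nitrile on its core, gives 3800 nM in this assay. Compound 3 `CC(O)(C(=O)Nc1ccc(S(=O)(=O)c2ccncc2)c(O)c1)C(F)(F)F`, with a pyridyl on the sulfonyl sulfur and a hydroxyl on its core, gives 1300 nM in this assay. Both of those gaps to compound 1 lie beyond the scatter, so compound 1 stands as the weakest inhibitor of the measured set.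

Compound 4 `CC(O)(C(=O)Nc1ccc(S(=O)(=O)c2cncs2)cc1)C(F)(F)F` is the next one to test. It differs from compound 1 in one place: 1,3-thiazol-5-yl in place of 3-hydroxyphenyl on a sulfonyl sulfur. Among the measured compounds shown here, no measured pair isolates this kind of exchange on the sulfonyl sulfur, so no step size is known for it. The hydroxyl donor is given up and a second acceptor comes in on a smaller ring; the measured compounds do not show whether that helps. A small step toward a lower number is expected, within the scatter or just beyond it, as a 1.5-fold lower number from compound 1 to compound 4 (0.18 log units; within the scatter). Compound 4 is therefore expected to give about 12000 nM in this assay, within a range of 3500 nM to 40000 nM.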

Compound 4, half-maximal inhibitory concentration: 7700 nM
Compound 4: middle estimate off by 1.6-fold (0.19 log units), on the high side; low and high end bracket the measured number.
By their numbers in this assay, from the lowest: compound 3; then compound 2; then compound 4; then compound 1.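

Among the compounds shown here, at the sulfonyl sulfur of the shared core, the exchange of 3-hydroxyphenyl for 1,3-thiazol-5-yl gives the first step that can be read in one place: in this assay it is a 2.3-fold lower number from compound 1 to compound 4 (0.37 log units; beyond the scatter) and counts as modest. The number at this position therefore does not depend on keeping the 3-hydroxyphenyl group, since compound 4 sits lower with a five-membered aromatic ring with 2 hetero atoms and 0 hydrogen-bond donors on the sulfonyl sulfur. No measurement shown here explains the step, so it stands as an observation only.

Ring size, hetero atoms and the hydroxyl all change together in this one exchange, so the compounds shown do not tell which of these accounts for the step. Also open, going by these compounds, is how the sulfonyl position responds to a ring carrying an amine or a carboxylic acid, and whether such groups would move the number further in the same direction or back toward that of compound 1.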